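One Amide Side Chain, Three Results, One Open Question

A few compounds are considered here, and "the series" means these few. Any claim that something is new, unique, unknown or untested is made for them only; others in the source may bear on it.

Compound 1 `CCn1c(C(=O)N[C@@H](C)C(=O)OC)ccc1C(CC)(CC)c1ccc(OCS(=O)(=O)c2ccccc2)c(C)c1`, compound 2 `CCn1c(C(=O)N[C@@H](C)CO)ccc1C(CC)(CC)c1ccc(OCS(=O)(=O)c2ccccc2)c(C)c1` and compound 3 `CCn1c(C(=O)N[C@H](CO)C(C)C)ccc1C(CC)(CC)c1ccc(OCS(=O)(=O)c2ccccc2)c(C)c1` share a core and differ only in the group on the amide-type nitrogen. In a functional assay on BXPC-3 cells (Homo sapiens) for antiproliferative activity, read by MTT assay, with a stated time of 24 h (a lower number here means a stronger inhibitor, a higher number a weaker inhibitor), compound 1 gives 17900 nM, compound 2 gives 15300 nM and compound 3 gives 7720 nM. Compound 3 therefore stands within the scatter of compound 2, and beyond the scatter below compound 1.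

Compound 4 `CCn1c(C(=O)N[C@@H](CO)CCO)ccc1C(CC)(CC)c1ccc(OCS(=O)(=O)c2ccccc2)c(C)c1` has 3-hydroxy-1-(hydroxymethyl)propyl in place of 1-(hydroxymethyl)-2-methylpropyl on the amide-type nitrogen, a change summed up as 3-hydroxy-1-(hydroxymethyl)propyl in place of 1-(hydroxymethyl)-2-methylpropyl on an amide-type nitrogen. Among the measured compounds shown here, no measured compound carries this new group, so the evidence is indirect. Changes at this nitrogen have so far been small, as shown by a 1.2-fold lower number from compound 1 to compound 2 (0.07 log units; within the scatter) and a 2.3-fold lower number from compound 1 to compound 3 (0.37 log units; beyond the scatter). The closest guide is the swap of methyl for isopropyl, which gave a 2.0-fold lower number from compound 2 to compound 3 (0.30 log units; within the scatter). Compound 4 no longer has the isopropyl end, so a small move back is expected. The expected step in this assay is a 1.6-fold higher number from compound 3 to compound 4 (0.19 log units; within the scatter), towards a higher number. For compound 4 the estimated value is 12000 nM, with an expected range of 6000 nM to 24000 nM.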

Compound 4, half-maximal inhibitory concentration: > 50000 nM
Compound 4 gave a limit, no number; the forecaster's own chance of this, stated with the estimate: 5%; at least 4.1-fold (0.61 log units) between middle value and limit.
By their numbers in this assay, from the lowest: compounds 3, 2 and 1 (each within the scatter of the next, the first and the last beyond it). At a limit, above all of these: compound 4.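

In this assay compound 4 gives a limit and not a number: the limit of > 50000 nM in this assay, at which 1 of the 4 values shown sits. Earlier changes on the amide-type nitrogen had produced only modest steps, yet 3-hydroxy-1-(hydroxymethyl)propyl in place of 1-(hydroxymethyl)-2-methylpropyl, a swap of one carbon for one oxygen at an unchanged 6 heavy atoms, gives an at least 6.4-fold higher number from compound 3 to compound 4 (0.81 log units; beyond the scatter). The other two side chains show the same direction, with an at least 3.2-fold higher number from compound 2 to compound 4 (0.51 log units; beyond the scatter) and an at least 2.7-fold higher number from compound 1 to compound 4 (0.44 log units; beyond the scatter), so this position is more sensitive to the choice of group than the first three compounds showed.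

The true size of these steps remains unknown, and the compounds shown do not separate the effect of the added hydroxyl from that of losing the isopropyl end. On these data alone, how a 3-amino-1-(hydroxymethyl)propyl or a 3-methoxy-1-(hydroxymethyl)propyl group on the same nitrogen would read also stays open.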